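A Chlorine Added to the Benzyl Arm in Compound 4

This account rests on a few compounds, and the source may have more. Where it says the series, first, only, none or still open, it means among the compounds named here.

Of the compounds shown here, three built on one shared core have been tested in a functional assay on HCT-116 cells (Homo sapiens) for inhibition, read by MTT assay, with a stated time of 72 h; a higher number here means a weaker inhibitor, a lower number a stronger inhibitor. Compound 1 `CCOC(=O)c1oc2ccc(N(Cc3ccccc3)S(=O)(=O)c3cccc(Cl)c3)cc2c1C` returns only a limit of the assay, > 40000 nM. Compound 2 `CCOC(=O)c1oc2ccc(N(Cc3ccccc3)S(=O)(=O)c3ccccc3)cc2c1C` likewise returns only a limit, > 40000 nM. Among the compounds with values here, compound 3 `Cc1c(C(=O)O)oc2ccc(N(Cc3ccccc3)S(=O)(=O)c3ccc(Cl)cc3)cc12` is the sole compound with a number: in this assay compound 3 gives 33400 nM. The step that the two limits leave unreadable from compound 2 to compound 1 cannot be sized because of the limit of > 40000 nM in this assay, at which 2 of the 3 values shown sit. The difference between the cores of compound 2 and compound 3 is not broken down here.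

Compound 4 `Cc1c(C(=O)O)oc2ccc(N(Cc3ccc(Cl)cc3)S(=O)(=O)c3ccc(Cl)cc3)cc12` has not been measured. It differs from compound 3 by chloro in place of hydrogen on an aromatic carbon. Compound 1 differs from compound 2 by chloro in place of hydrogen on an aromatic carbon. These are the same kind of change, not the same: in compound 4 the chloro sits para to a large group and the difference reads benzyl to 4-chlorobenzyl, whereas in compound 1 it sits meta to a large group and reads phenylsulfonyl to (3-chlorophenyl)sulfonyl.

The step expected here is a 1.1-fold lower number from compound 3 to compound 4 (0.05 log units; within the scatter). That expectation rests on compound 3 at 33400 nM. It also rests on the step that the two limits leave unreadable from compound 2 to compound 1, whose size the limits hide. Compound 4 is therefore estimated at 30000 nM, between 12000 nM and 80000 nM in this assay.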

Compound 4, half-maximal inhibitory concentration: 27200 nM
Compound 4: the middle estimate sits 1.1-fold (0.04 log units) above what was measured, and the stated range covers the measured number.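

In this assay, chloro in place of hydrogen on the benzyl arm gives a 1.2-fold lower number from compound 3 to compound 4 (0.09 log units; within the scatter), so on this core the change leaves compound 3 and compound 4 indistinguishable by this read-out. This is a single reading on one core, and it says nothing on its own about how chloro behaves on the core of compound 1, where the chloro also stands in a different place. The data therefore show neither that the change carries over from one core to the other nor that it fails to, because the step from compound 2 to compound 1 cannot be read, both compounds returning only limits of the assay: the limit of > 40000 nM in this assay, at which 2 of the 4 values shown sit.

The compounds shown leave open whether a different group on the benzyl arm, such as an amine or a methoxy group, would give a step from compound 3 beyond the scatter. They also leave open how an amide in place of the carboxylic acid of compound 3 would read in this assay.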